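From compound 2 to compound 3: a benzyl swap

This account rests on a few compounds, and the source may have more. Where it says the series, first, only, none or still open, it means among the compounds named here.

Compound 1 `OC[C@H]1O[C@@H](n2cnc3c(NCc4cccc(F)c4)ncnc32)[C@H](O)[C@@H]1O`: 7600 nM
Compound 2 `OC[C@H]1O[C@@H](n2cnc3c(NCc4ccc(F)cc4F)ncnc32)[C@H](O)[C@@H]1O`: 9600 nM

In a functional assay on K562 cells (Homo sapiens) for antiproliferative activity, with a stated time of 72 h (on this read-out higher numbers stand for weaker inhibition and lower numbers for stronger inhibition), compound 1 gives 7600 nM and compound 2 gives 9600 nM as its measured value. Only these two numbers exist so far, and they lie within the scatter of each other, so compound 2 cannot be ranked against compound 1.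

Compound 3 `OC[C@H]1O[C@@H](n2cnc3c(NCc4ccc(F)c(Cl)c4)ncnc32)[C@H](O)[C@@H]1O` has not been measured yet. It carries 3-chloro-4-fluorophenyl in place of 2,4-difluorophenyl on a saturated chain carbon bound to a nitrogen on an aromatic ring, and the change counts as 3-chloro-4-fluorophenyl in place of 2,4-difluorophenyl on a saturated chain carbon bound to a nitrogen on an aromatic ring in full.

Within the data shown here, one measured step bears on this swap, since it also replaces one fluorinated phenyl group with another at the same place. That step is a 1.3-fold higher number from compound 1 to compound 2 (0.10 log units; within the scatter) and it stays small. Among the measured compounds shown here, no measured compound carries 3-chloro-4-fluorophenyl, so the range is kept wide.

The expected step is a 1.2-fold lower number from compound 2 to compound 3 (0.08 log units; within the scatter) and nothing beyond the scatter is expected in this assay here. Compound 3 is estimated at 8000 nM with an expected range from 3500 nM to 18000 nM once tested.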

Compound 3, half-maximal inhibitory concentration: 5500 nM
The estimate for compound 3 lay 1.5-fold (0.16 log units) above the measured number, and the stated range covers the measured number.
By their numbers in this assay, from the lowest: compounds 3, 1 and 2 (each within the scatter of the next).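

In this assay the swap from 2,4-difluorophenyl to 3-chloro-4-fluorophenyl gives a 1.7-fold lower number from compound 2 to compound 3 (0.24 log units; within the scatter) and the swap from 3-fluorophenyl to the same group gives a 1.4-fold lower number from compound 1 to compound 3 (0.14 log units; within the scatter) on the saturated chain carbon bound to a nitrogen on an aromatic ring. Among these compounds, this is the first sign that a chlorine can enter this group, in addition to fluorine, without moving the number beyond the usual scatter, so all three halogen-bearing phenyl groups now sit within the scatter of one another and cannot be ranked. Nothing on hand explains these numbers or says what the chlorine does here.

The swaps change more than one ring substituent at once, so the compounds shown cannot separate the effect of the chlorine from that of where the halogens sit. Also open, going by these compounds, is whether a plain phenyl group with no halogen, a phenyl group carrying a methoxy group, an amine or a carboxylic acid, or a longer chain linking the ring to the nitrogen would give a number that lies beyond the scatter of these three.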